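Extending a Formyl Group to a (tert-Butyl)carbamoyl

The source may report more compounds than this note shows. Statements on the series, on what has been measured and on what is new or still open speak of the compounds shown alone.

Compound 1 `COc1ccc2c(c1)OC(c1cc(OC)c(OC)c(OC)c1)C(C(=O)OC(C)(C)C)=C2`: 14100 nM
Compound 2 `COc1ccc2c(c1)OC(c1cc(OC)c(OC)c(OC)c1)C(C=O)=C2`: 13500 nM

In a functional assay for inhibition of nuclear factor NF-kappa-B complex (Homo sapiens) (a lower number here means a stronger inhibitor, a higher number a weaker inhibitor), compound 2 gives 13500 nM, the lower of the two numbers shown, though the only measured step, a 1.0-fold lower number from compound 1 to compound 2 (0.02 log units; within the scatter), lies within the scatter, so the two compounds cannot be ordered. Compound 3 `COc1ccc2c(c1)OC(c1cc(OC)c(OC)c(OC)c1)C(C(=O)NC(C)(C)C)=C2` differs from compound 2 in one place: (tert-butyl)amino in place of hydrogen on a carbonyl carbon. Among the measured compounds shown here, the one step that bears on this position, hydrogen for tert-butoxy, was flat, so a step of no size beyond the scatter is expected, no change at the digits printed from compound 2 to compound 3 (within the scatter). Compound 3 is therefore estimated at 13500 nM, with a range from 5000 nM to 36000 nM.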

Compound 3, half-maximal inhibitory concentration: 28400 nM
The estimate for compound 3 lay 2.1-fold (0.32 log units) below the measured number; measured number inside the range.
By their numbers in this assay, from the lowest: compounds 2, 1 and 3 (each within the scatter of the next, the first and the last beyond it).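

In this assay, the carbonyl carbon no longer looks flat: with (tert-butyl)amino in place of hydrogen, the data show a 2.1-fold higher number from compound 2 to compound 3 (0.32 log units; beyond the scatter), a modest weakening. The tert-butoxy and (tert-butyl)amino groups remain unseparated, as a 2.0-fold higher number from compound 1 to compound 3 (0.30 log units; within the scatter), stays within the scatter. No measurement shown here offers an explanation for the step.

The compounds shown leave open whether the nitrogen or the tert-butyl group carries the change. A methylamino group or a carboxylic acid on this carbonyl carbon could help settle how far the position tolerates change.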